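A few compounds are considered here, and "the series" means these few. Any claim that something is new, unique, unknown or untested is made for them only; others in the source may bear on it.

Of the compounds shown here, three sharing one core have been tested in a functional assay on HCT-116 cells (Homo sapiens) for antiproliferative activity, read by MTT assay, with a stated time of 72 h; a higher number here means a weaker inhibitor, a lower number a stronger inhibitor. Compound 1 `CN(C(=O)CCc1ccccc1)c1ccc2[nH]c(-c3n[nH]c4ccccc34)cc2n1` gives 11200 nM in this assay, compound 2 `COc1cccc(C(=O)N(C)c2ccc3[nH]c(-c4n[nH]c5ccccc45)cc3n2)c1` gives 14200 nM, and compound 3 `CN(c1ccc2[nH]c(-c3n[nH]c4ccccc34)cc2n1)S(=O)(=O)c1ccc(Cl)cc1` gives 5980 nM. Compound 3 has the lowest of the three numbers: against compound 1 the gap is a 1.9-fold lower number from compound 1 to compound 3 (0.27 log units; within the scatter), which keeps the two on the same footing, while against compound 2 it is a 2.4-fold lower number from compound 2 to compound 3 (0.38 log units; beyond the scatter), a modest separation. Between compounds 1 and 2 the step is a 1.3-fold higher number from compound 1 to compound 2 (0.10 log units; within the scatter).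

Compound 4 `COc1ccc(OC)c(S(=O)(=O)N(C)c2ccc3[nH]c(-c4n[nH]c5ccccc45)cc3n2)c1` differs from compound 3 in one place: 2,5-dimethoxyphenyl in place of 4-chlorophenyl on a sulfonyl sulfur. Among the compounds with values here, no measured step alters the aryl group on the sulfonyl sulfur, so no direct precedent exists. The nearest comparison is the exchange of one aryl-type group for another on the carbonyl carbon, a 1.3-fold higher number from compound 1 to compound 2 (0.10 log units; within the scatter), which produced no movement beyond the scatter. On that basis the expected step of a 1.3-fold higher number from compound 3 to compound 4 (0.10 log units; within the scatter) is small, in either direction, and most likely not beyond the scatter, with a slight lean toward a higher number given that the whole series sits within a narrow span. Compound 4 is therefore estimated at 7500 nM in this assay, within a range from 2500 nM to 22000 nM.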

Compound 4, half-maximal inhibitory concentration: 8400 nM
For compound 4 the middle estimate is 1.1-fold (0.05 log units) below the measured one; measured number inside the range.
By their numbers in this assay, from the lowest: compounds 3, 4, 1 and 2 (each within the scatter of the next, the first and the last beyond it).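

In this assay, within the data shown here, the exchange of 4-chlorophenyl for 2,5-dimethoxyphenyl on a sulfonyl sulfur whose other neighbour is the sulfonamide nitrogen gives a 1.4-fold higher number from compound 3 to compound 4 (0.15 log units; within the scatter), the first step in this set that alters the aryl group at this place. The group that enters has 2 hydrogen-bond acceptors and 10 heavy atoms, against 0 acceptors and 7 heavy atoms for the group that leaves, yet this difference in make-up does not separate the two compounds beyond the scatter. Nothing given here accounts for this outcome.

The compounds shown leave open whether any group on the sulfonyl sulfur can move the number beyond the scatter, for instance a plain methyl, or a phenyl carrying an amine or a carboxylic acid, and they do not show what each methoxy group or the loss of the chlorine contributes on its own. From the compounds shown here alone, the methyl on the nitrogen is also shared by all four compounds, so what a hydrogen or a longer chain would do in its place remains unknown.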